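Ethyl for tert-butyl on the amide of compound 1

The compounds below may be only part of what the source reports. "The series", "measured", "known", "first", "only" and "open" are said of these compounds alone.

Compound 1 `Cn1c(-c2ccc(C(=O)NC(C)(C)C)cc2)nnc1C1(c2ccc(Cl)cc2)CCC1` gives a limit in an assay on isolated protein for inhibition of 11-beta-hydroxysteroid dehydrogenase type 2 (Mus musculus) (on this read-out higher numbers stand for weaker inhibition and lower numbers for stronger inhibition), of > 4000 nM.
Compound 2 `CC(=O)Nc1ccc(-c2nnc(C3(c4ccc(Cl)cc4)CCC3)n2C)c(Cl)c1` gives a limit of > 4000 nM.
Compound 3 `Cn1c(-c2ccc(C(=O)O)cc2Cl)nnc1C1(c2ccc(Cl)cc2)CCC1` gives a limit of > 4000 nM.

All three measured compounds sit at a limit (the limit of > 4000 nM in this assay, at which 3 of the 3 values shown sit), so compound 1 stands at the limit rather than at a number. Among the measured compounds shown here, the one measured step, a step that the two limits leave unreadable from compound 2 to compound 3, is unreadable for the same reason and says nothing about size or direction. Compound 4 `CCNC(=O)c1ccc(-c2nnc(C3(c4ccc(Cl)cc4)CCC3)n2C)cc1` differs from compound 1 by ethyl in place of tert-butyl on an amide-type nitrogen. For the measured compounds named here, no measured step touches this amide-type nitrogen, so the change is uninformed by the data. Compound 4 is estimated at 6000 nM, within 2500 nM to 20000 nM, and the expected step that the limit leaves unreadable from compound 1 to compound 4 most likely leaves it at the limit.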

Compound 4, half-maximal inhibitory concentration: > 4000 nM
Compound 4 gave a limit, no number; the forecaster's own chance of this, stated with the estimate: 80%; the middle value does not contradict the limit.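

Among the compounds shown here, compound 1 and compound 4 both give only a limit, so no step between them can be read: the limit of > 4000 nM in this assay, at which 4 of the 4 values shown sit. The compounds shown leave open whether tert-butyl and ethyl on the amide-type nitrogen differ at all.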